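From furan-2-yl to thiophen-3-yl: a close swap

A few compounds are considered here, and "the series" means these few. Any claim that something is new, unique, unknown or untested is made for them only; others in the source may bear on it.

In a functional assay on HCT-116 cells (Homo sapiens) for inhibition, with a stated time of 72 h (a lower number here means a stronger inhibitor, a higher number a weaker inhibitor), compound 1 (`COc1ccccc1-c1ccc(CNc2nc(NC3CCC(N)CC3)nc3c2ncn3C2CCCC2)cc1`) gives 430 nM as its reading. Among the measured compounds shown here, compound 2 (`NC1CCC(Nc2nc(NCc3ccc(-c4ccco4)cc3)c3ncn(C4CCCC4)c3n2)CC1`) gives 129 nM and so holds the lower of the two numbers measured so far, which marks it as the stronger inhibitor. Compound 3 (`NC1CCC(Nc2nc(NCc3ccc(-c4ccsc4)cc3)c3ncn(C4CCCC4)c3n2)CC1`) keeps the shared core and alters one group, with thiophen-3-yl in place of furan-2-yl on an aromatic carbon. For the measured compounds named here, the only measured step at this position is a 3.3-fold lower number from compound 1 to compound 2 (0.52 log units; beyond the scatter) and it came with furan-2-yl in place of 2-methoxyphenyl. That modest step replaced a quite different group, whereas the new change trades one five-membered aromatic ring with 1 hetero atom for another. On these data alone, no step beyond the scatter is therefore expected in this assay and the direction stays open. The estimated step is a 1.2-fold higher number from compound 2 to compound 3 (0.07 log units; within the scatter) and it should remain small. For compound 3 the expected value is 150 nM (estimated range 65 nM to 350 nM).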

Compound 3, half-maximal inhibitory concentration: 315 nM
The estimate for compound 3 lay 2.1-fold (0.32 log units) below the measured number, within the range that was stated.
By their numbers in this assay, from the lowest: compound 2; then compounds 3 and 1 (each within the scatter of the next).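

In this assay, this position responds even to a close swap: a 2.4-fold higher number from compound 2 to compound 3 (0.39 log units; beyond the scatter), although furan-2-yl and thiophen-3-yl are both five-membered aromatic rings with 1 hetero atom, 5 heavy atoms and the same donor and acceptor counts. The comparison with the earlier group adds a second point, a 1.4-fold lower number from compound 1 to compound 3 (0.14 log units; within the scatter), so thiophen-3-yl and 2-methoxyphenyl cannot be told apart here, and among these three compounds only the furan-2-yl of compound 2 stands apart. Nothing available here explains the gap between the furan-2-yl and thiophen-3-yl compounds.

The swap changes both the hetero atom, oxygen to sulfur, and the ring position through which the group is attached, so the compounds shown cannot separate these two changes. Furan-3-yl and thiophen-2-yl would pull them apart, while pyridin-3-yl would show how a six-membered aromatic ring with a nitrogen atom fares at this position.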